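Benzyl on the ring nitrogen of the bromo compound

The source may hold more compounds than are shown below. What is called first, only, known or untested is meant among the compounds shown, and "the series" means these compounds.

Within the data shown here, in a functional assay on KYSE-410 cells (Homo sapiens) for antiproliferative activity, read by MTT assay, with a stated time of 72 h (on this read-out lower numbers stand for stronger inhibition and higher numbers for weaker inhibition), compound 1 `O=C(Nc1cccc(F)c1)c1cc(=O)[nH]c2cc(Br)ccc12` gives 7300 nM, the only true number so far. Compound 2 `O=C(Nc1cccc(F)c1)c1cc(=O)[nH]c2cc(-c3ccccc3)ccc12` reads > 20000 nM in this assay, which is a limit of the assay. Compound 3 `Cc1ccc(-c2ccc3c(C(=O)Nc4cccc(F)c4)cc(=O)[nH]c3c2)cc1` reads > 20000 nM in this assay, which is also a limit.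

Compound 4 `O=C(Nc1cccc(F)c1)c1cc(=O)n(Cc2ccccc2)c2cc(Br)ccc12` keeps the bromo group of compound 1 and differs elsewhere: benzyl in place of hydrogen on an aromatic nitrogen, in short benzyl in place of hydrogen on an aromatic nitrogen. Among the measured compounds shown here, no measured step touches that nitrogen, so the evidence is indirect. The nearest guides are changes on an aromatic carbon. Phenyl in place of bromo gives an at least 2.7-fold higher number from compound 1 to compound 2 (0.43 log units; beyond the scatter), and 4-methylphenyl in place of bromo gives an at least 2.7-fold higher number from compound 1 to compound 3 (0.43 log units; beyond the scatter). Both steps add an aromatic ring to the shared core, and both lead towards weaker inhibition, although at a different place from the new benzyl group. On that basis, a small shift in the same direction seems more likely than a gain. The expected step is a 1.8-fold higher number from compound 1 to compound 4 (0.25 log units; within the scatter), a rise not clearly beyond the scatter, and a result at the limit of the assay remains possible. For compound 4 the estimated value is 13000 nM, with an expected range of 4000 nM to 20000 nM.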

Compound 4, half-maximal inhibitory concentration: > 20000 nM
Compound 4 was reported as a limit (the forecaster's own chance of this, stated with the estimate: 35%); middle value at least 1.5-fold (0.18 log units) away from the limit.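

Among these compounds, on the ring nitrogen, a place that no earlier step touched, benzyl in place of hydrogen gives an at least 2.7-fold higher number from compound 1 to compound 4 (0.43 log units; beyond the scatter) in this assay. Among the compounds shown here, the loss seen earlier, when an aromatic ring took the place of bromo on an aromatic carbon, is therefore not confined to that carbon: a benzyl group on the nitrogen, with the bromo group kept, also leads towards weaker inhibition, and compound 1, with hydrogen on this nitrogen and bromo on that carbon, remains the only compound of the four with a true number. The new step gives only a lower bound on the change, and the step between compound 2 and compound 3 cannot be read at all, with most of the series resting on one limit: the limit of > 20000 nM in this assay, at which 3 of the 4 values shown sit.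

In compound 4 the loss of the hydrogen and the arrival of the benzyl group are a single change, so the compounds shown cannot tell which of the two matters. As far as these compounds go, it also stays open whether an ethyl group, or a longer chain ending in an amine, on this nitrogen would return a true number in this assay.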